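Swapping the dihydroxyphenyl of compound 1 for a dimethoxyphenyl

This account rests on a few compounds, and the source may have more. Where it says the series, first, only, none or still open, it means among the compounds named here.

Of the compounds shown here, three sharing one core have been tested in an assay on isolated protein for inhibition of Maltase-glucoamylase (Homo sapiens), with a stated time of 15 min; a higher number here means a weaker inhibitor, a lower number a stronger inhibitor. Among the measured compounds shown here, compound 1 `O=C(N/N=C/c1cccc(O)c1O)c1ccc(-c2nc3ccccc3s2)cc1` is the only one with a number: in this assay compound 1 gives 11200 nM. Compound 2 `COC(=O)c1ccc(/C=N/NC(=O)c2ccc(-c3nc4ccccc4s3)cc2)cc1` is reported in this assay as "not active" (no number reported), without a number. Compound 3 `COc1ccc(/C=N/NC(=O)c2ccc(-c3nc4ccccc4s3)cc2)cc1OC` is likewise reported in this assay as "not active" (no number reported). So compound 1 stands alone as the one measurable inhibitor among the three, and no step between two measured compounds can be sized.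

Compound 4 `COc1cc(/C=N/NC(=O)c2ccc(-c3nc4ccccc4s3)cc2)cc(OC)c1` has not been measured. It differs from compound 1 in one place: 3,5-dimethoxyphenyl in place of 2,3-dihydroxyphenyl on a carbon with a double bond to nitrogen. Compound 3 also carries two methoxy groups and no hydroxyl on that ring and came out without a number, and compound 2 also lacks a hydroxyl there and came out the same way. Compound 4 is therefore expected to be weaker than compound 1, with the step from a 3.6-fold higher number from compound 1 to compound 4 (0.55 log units; beyond the scatter) expected to go well beyond the usual scatter, and a fair chance that only "not active" is reported. The estimate for compound 4 in this assay is 40000 nM, within a range from 12000 nM to 150000 nM.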

Compound 4, half-maximal inhibitory concentration: 16200 nM
Compound 4: middle estimate off by 2.5-fold (0.39 log units), on the high side; the range from low to high includes it.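

In this assay, putting 3,5-dimethoxyphenyl in place of 2,3-dihydroxyphenyl on a carbon with a double bond to nitrogen gives a 1.4-fold higher number from compound 1 to compound 4 (0.16 log units; within the scatter), so this change cannot be told apart from repeat-measurement noise. A measurable number at this position therefore does not depend on hydroxyl groups: the entering group has 0 hydrogen-bond donors, yet compound 4 still gives a value, whereas compound 2 and compound 3, which also have no hydroxyl on this ring, are reported as "not active". No measurement shown accounts for this outcome.

The compounds shown leave open whether 3,5-dihydroxyphenyl or 2,3-dimethoxyphenyl would behave like compound 1 or compound 4, which would separate the choice of group from its placement. Going by these compounds, how an amine or a carboxylic acid on this ring would fare also remains open.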